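The source may hold more compounds than are shown below. What is called first, only, known or untested is meant among the compounds shown, and "the series" means these compounds.

Compound 3 `O=C(CCCc1ccccc1)Nc1ccc(N2CCN(c3ccc(OC[C@@H]4CO[C@@](Cn5cncn5)(c5ccc(Cl)cc5Cl)O4)cc3)CC2)cc1` belongs to a small set of compounds that share one core and differ only in the group bound to the carbonyl carbon of the amide. In a functional assay on HepG2 cells (Homo sapiens) for inhibition, read by MTT assay, with a stated time of 48 h (on this read-out higher numbers stand for weaker inhibition and lower numbers for stronger inhibition), compound 3 gives 10800 nM. Compound 1 `O=C(CC1CCOCC1)Nc1ccc(N2CCN(c3ccc(OC[C@@H]4CO[C@@](Cn5cncn5)(c5ccc(Cl)cc5Cl)O4)cc3)CC2)cc1` gives 21100 nM in this assay, and compound 2 `O=C(CCCCc1ccccc1)Nc1ccc(N2CCN(c3ccc(OC[C@@H]4CO[C@@](Cn5cncn5)(c5ccc(Cl)cc5Cl)O4)cc3)CC2)cc1` gives 7010 nM. Compound 3 therefore stands second highest among the three measured values, with its nearest neighbour compound 2 and its furthest neighbour compound 1; both of those gaps are shown as within the scatter, namely a 1.5-fold higher number from compound 2 to compound 3 (0.19 log units; within the scatter) and a 2.0-fold lower number from compound 1 to compound 3 (0.29 log units; within the scatter). For the measured compounds named here, the only step beyond the scatter in this set is a 3.0-fold lower number from compound 1 to compound 2 (0.48 log units; beyond the scatter), and it is modest.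

Compound 4 `O=C(Nc1ccc(N2CCN(c3ccc(OC[C@@H]4CO[C@@](Cn5cncn5)(c5ccc(Cl)cc5Cl)O4)cc3)CC2)cc1)c1cccc(F)c1` differs from compound 3 in a single place: 3-fluorophenyl in place of 3-phenylpropyl on a carbonyl carbon. Going by the values given here, no measured step puts an aromatic ring directly on the carbonyl carbon, so the closest guidance comes from the steps that exchange the chain on that carbon, and those move the number little, at most a 3.0-fold lower number from compound 1 to compound 2 (0.48 log units; beyond the scatter). On that basis the change to compound 4 is expected to make no difference beyond the scatter, with the expected step being a 1.1-fold higher number from compound 3 to compound 4 (0.05 log units; within the scatter). Compound 4 is thus estimated to give about 12000 nM in this assay, within a range from 5000 nM to 30000 nM.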

Compound 4, half-maximal inhibitory concentration: 10800 nM
Beside the measured number, compound 4's estimate is 1.1-fold (0.05 log units) above it; the range from low to high includes it.
By their numbers in this assay, from the lowest: compounds 2, 3, 4 and 1 (each within the scatter of the next, the first and the last beyond it).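

With 3-fluorophenyl on the carbonyl carbon, the aromatic ring now sits directly on that carbon, and the exchange for 3-phenylpropyl leaves the reading in this assay unchanged (no change at the digits printed from compound 3 to compound 4 (within the scatter)), so the saturated chain of compound 3 is not needed to keep the number where it stands. The new group also stays within the scatter of the other two groups (a 1.5-fold higher number from compound 2 to compound 4 (0.19 log units; within the scatter); a 2.0-fold lower number from compound 1 to compound 4 (0.29 log units; within the scatter)), even though compound 1 and compound 2 lie beyond the scatter of each other, which places compound 4 in the middle of the narrow band these amides occupy and shows that an aromatic acyl group and saturated-chain acyl groups read alike here. No measurement at hand explains why these different groups give such similar numbers.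

Going by these compounds, what a plain phenyl on the carbonyl carbon would give remains open, and with it whether the fluorine of compound 4 counts for anything at all. Also open, on these data alone, is whether a carboxylic acid or an amine at the end of the chain on this carbon would move the number out of this band.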